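This account rests on a few compounds, and the source may have more. Where it says the series, first, only, none or still open, it means among the compounds named here.

Two measured compounds share one core. Compound 1 `Cc1ccc(NC(=O)Nc2cccc(CNc3ncnc4ccccc34)c2)cc1` gives 31200 nM in a functional assay on MGC-803 cells (Homo sapiens) for antiproliferative activity, read by MTT assay; on this read-out lower numbers stand for stronger inhibition and higher numbers for weaker inhibition. Compound 2 `O=C(Nc1ccc(F)cc1)Nc1cccc(CNc2ncnc3ccccc23)c1` gives 44300 nM in this assay, and these two numbers sit within the usual scatter of each other, so neither can be called the stronger. For the measured compounds named here, the only measured step, a 1.4-fold higher number from compound 1 to compound 2 (0.15 log units; within the scatter), swaps fluoro for methyl on an aromatic carbon and does not move the number beyond the scatter.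

Compound 3 `O=C(Nc1cccc(CNc2ncnc3ccccc23)c1)Nc1ccccc1Cl` is not yet measured. It differs from compound 2 by 2-chlorophenyl in place of 4-fluorophenyl on an amide-type nitrogen. Going by the values given here, the one measured step bears on it only loosely, since it changes the same ring but with a different group, and it was within the scatter; nothing else in hand speaks to this change. On that basis the step of a 1.1-fold lower number from compound 2 to compound 3 (0.04 log units; within the scatter) is expected to stay within the scatter, in no clear direction. Compound 3 is therefore estimated at 40000 nM in this assay, with a range from 14000 nM to 110000 nM.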

Compound 3, half-maximal inhibitory concentration: > 50000 nM
Compound 3: no number, only a limit; the forecaster's own chance of this, stated with the estimate: 20%; middle value at least 1.2-fold (0.09 log units) from the limit.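

For compound 3, > 50000 nM in this assay is a limit and not a number. Putting 2-chlorophenyl on the amide-type nitrogen in place of 4-fluorophenyl gives an at least 1.1-fold higher number from compound 2 to compound 3 (0.05 log units; that floor lies within the scatter), and putting it in place of 4-methylphenyl gives an at least 1.6-fold higher number from compound 1 to compound 3 (0.20 log units; that floor lies within the scatter). These floors show no sign of stronger inhibition with this third group at this position, but the true size of each step stays unknown, and the reading rests on this: the limit of > 50000 nM in this assay, at which 1 of the 3 values shown sits.

The compounds shown cannot separate the swap of fluorine for chlorine from the shift in where the halogen sits on the ring. They also leave open how this assay would read with a phenyl ring carrying an amine or a carboxylic acid, or with a longer chain in place of the ring.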